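Series notes: hydrogen in place of methoxy on compound 2

A few compounds are considered here, and "the series" means these few. Any claim that something is new, unique, unknown or untested is made for them only; others in the source may bear on it.

Three compounds of one series share a core in which a trifluoromethyl-bearing diol amide is joined through a chain to a second amide carrying an aromatic group. Compound 1 `O=C(CCCCCCNC(=O)C(O)(O)C(F)(F)F)Nc1ccc(Br)cc1` gives 3130 nM in a functional assay on HCT-116 cells (Homo sapiens) for inhibition, read by colorimetric assay, with a stated time of 3 days; a higher number here means a weaker inhibitor, a lower number a stronger inhibitor. Compound 2 `COc1ccc(NC(=O)CCCCCCNC(=O)C(O)(O)C(F)(F)F)cc1` gives 4520 nM in this assay. Compound 3 `Cc1nc(NC(=O)CCCCCCNC(=O)C(O)(O)C(F)(F)F)sc1-c1ccccc1` gives 10100 nM in this assay. Compound 2 thus stands second highest of the three numbers; its gap to compound 1 lies within the scatter, so no order between those two can be stated, while its gap to compound 3 lies beyond the scatter.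

Within the data shown here, the one measured step, a 1.4-fold higher number from compound 1 to compound 2 (0.16 log units; within the scatter), exchanges methoxy for bromo on an aromatic carbon and stays within the scatter.

Compound 4 `O=C(CCCCCCNC(=O)C(O)(O)C(F)(F)F)Nc1ccccc1` differs from compound 2 by hydrogen in place of methoxy on an aromatic carbon. Among the measured compounds shown here, the only measured step that bears on this, a 1.4-fold higher number from compound 1 to compound 2 (0.16 log units; within the scatter), swaps one group for another on the same aromatic carbon and was within the scatter. For the measured compounds named here, no measured pair removes the group entirely. On that basis no step beyond the scatter is expected in this assay, the expected step being a 1.1-fold higher number from compound 2 to compound 4 (0.04 log units; within the scatter). Compound 4 is therefore estimated at 5000 nM, with a range from 2200 nM to 11000 nM.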

Compound 4, half-maximal inhibitory concentration: 9140 nM
Compound 4: the middle estimate sits 1.8-fold (0.26 log units) below what was measured, and the stated range covers the measured number.
By their numbers in this assay, from the lowest: compounds 1 and 2 (each within the scatter of the next); then compounds 4 and 3 (each within the scatter of the next).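

In this assay, removing the substituent from this aromatic carbon makes a readable difference where exchanging one substituent for another did not: hydrogen in place of methoxy gives a 2.0-fold higher number from compound 2 to compound 4 (0.31 log units; beyond the scatter), and hydrogen in place of bromo gives a 2.9-fold higher number from compound 1 to compound 4 (0.47 log units; beyond the scatter). Among the three compounds that differ only at this carbon, compound 4 has the highest number, so either substituent goes with a lower number than hydrogen, although both steps remain modest and methoxy and bromo cannot be ordered against each other. No supporting data are available to explain this difference.

On these data alone, it remains open whether other groups on this carbon, such as a nitrile, an amine or a carboxylic acid, would follow methoxy and bromo or move the number further than either does. As far as these compounds go, it is also open whether the difference between a substituted and a bare phenyl would persist with a shorter or longer chain in the shared core.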